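This account rests on a few compounds, and the source may have more. Where it says the series, first, only, none or still open, it means among the compounds named here.

Values in a functional assay on HeLa cells (Homo sapiens) for cytotoxicity, read by MTT assay, with a stated time of 24 h; a lower number here means a stronger inhibitor, a higher number a weaker inhibitor:
compound 1 `CN1C/C(=C\c2cccc([N+](=O)[O-])c2)C(=O)/C(=C/c2ccc(Cl)cc2Cl)C1`: 8900 nM
compound 2 `CN1C/C(=C\c2ccc(F)cc2)C(=O)/C(=C/c2ccc(C#N)cc2)C1`: 10200 nM
compound 3 `CN1C/C(=C\c2ccc(Cl)cc2)C(=O)/C(=C/c2ccc(C#N)cc2)C1`: 11200 nM

The three values lie within the scatter of one another, so compound 3 stands level with compound 1 and compound 2.

The next structure is compound 4 `CN1C/C(=C\c2ccc(C#N)cc2)C(=O)/C(=C/c2ccc(Cl)cc2Cl)C1`, in which 4-chlorophenyl becomes 2,4-dichlorophenyl: chloro in place of hydrogen on an aromatic carbon. The new chloro sits ortho to a large group and meta to the chloro group already present.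

For the measured compounds named here, only one measured step touches this aromatic group: a 1.1-fold higher number from compound 2 to compound 3 (0.04 log units; within the scatter). That step exchanges one halogen for another and adds no chloro, so it bears on the change only loosely. Going by the values given here, no measured pair isolates the added chloro. The 2,4-dichlorophenyl group already occurs with a different partner in compound 1, at 8900 nM, which is within the scatter of the other values. No step beyond the scatter is therefore expected in this assay, and no direction is favoured. The estimated step is a 1.1-fold lower number from compound 3 to compound 4 (0.06 log units; within the scatter). For compound 4 the expected value is 9800 nM, with an estimated range of 5000 nM to 19000 nM.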

Compound 4, half-maximal inhibitory concentration: 7760 nM
Compound 4: the middle estimate sits 1.3-fold (0.10 log units) above what was measured, and the stated range covers the measured number.
By their numbers in this assay, from the lowest: compounds 4, 1, 2 and 3 (each within the scatter of the next).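

In this assay, chloro in place of hydrogen on this aromatic carbon, ortho to a large group, gives a 1.4-fold lower number from compound 3 to compound 4 (0.16 log units; within the scatter) and so leaves 2,4-dichlorophenyl level with 4-chlorophenyl when the partner is 4-cyanophenyl. The larger exchanges read the same way: 2,4-dichlorophenyl in place of 4-fluorophenyl gives a 1.3-fold lower number from compound 2 to compound 4 (0.12 log units; within the scatter) and 4-cyanophenyl in place of 3-nitrophenyl gives a 1.1-fold lower number from compound 1 to compound 4 (0.06 log units; within the scatter) as well, so all four compounds stand level. Nothing on hand explains why these changes leave the values level.

On these data alone, whether any change on these aromatic rings can move the value beyond the scatter remains open. As far as these compounds go, what an amine or a carboxylic acid on these rings would give, or a longer chain in place of the methyl on the shared core, also remains open.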